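Phthalimide anilinomethyl series: urea extension of the aryl amine

A few compounds are considered here, and "the series" means these few. Any claim that something is new, unique, unknown or untested is made for them only; others in the source may bear on it.

Two compounds of this series have numbers in an assay on isolated protein for inhibition of ribosomal protein S6 kinase alpha-2 (Homo sapiens), read by fluorescence, with a stated time of 20 min, tested at 10 uM; on this read-out lower numbers stand for less inhibition and higher numbers for more inhibition at the one concentration tested (going by the name of the read-out). Compound 1 `COc1ccc(N(C)CN2C(=O)c3ccccc3C2=O)cc1` carries a methyl on the aniline nitrogen and no substituent on the phthalimide portion; in this assay compound 1 gives 87%. Compound 2 `COc1ccc(NCN2C(=O)c3ccc(N)cc3C2=O)cc1` has a free aniline hydrogen and an amino group on the aromatic ring of the core; in this assay compound 2 gives 109%, the higher of the two numbers, and its gap to compound 1 lies beyond the usual scatter. The two compounds differ in more than one place, so the two values show only that both sit at the high end of the read-out, with compound 2 at practical saturation.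

Compound 3 `COc1ccc(NCN2C(=O)c3ccc(NC(=O)Nc4ccccc4)cc3C2=O)cc1` follows from compound 2 by one change: phenylcarbamoyl in place of hydrogen on a nitrogen on an aromatic ring, so that the amino becomes a (phenylcarbamoyl)amino. Going by the values given here, no step of this kind has been measured, and nothing here tells how such an extension fares. Given that compound 2 already gives 109%, the expected step of a number 14 percentage points lower from compound 2 to compound 3 (beyond the scatter) is small, downward if anything, and within the scatter. Compound 3 is expected to give 95%, in the range 65% to 110%.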

Compound 3, a percentage reported as inhibition, at one concentration (the size of the read-out at that concentration, not a potency): 34.8%
Compound 3: middle estimate off by 60.2 percentage points, on the high side; measured number below the stated range.
By their numbers in this assay, from the lowest: compound 3; then compound 1; then compound 2.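

In this assay, going by these compounds alone, phenylcarbamoyl in place of hydrogen on a nitrogen on an aromatic ring gives a number 74.2 percentage points lower from compound 2 to compound 3 (beyond the scatter), the first step that can be read as a single change. The high numbers of compound 1 and compound 2 gave no sign that inhibition at the one concentration tested depends on what this nitrogen carries; this step shows that it does, at least for the amino to (phenylcarbamoyl)amino change. No measurement at hand bears on why the number falls so far.

Still open, as far as these compounds go, is whether the drop goes with the urea linkage or with the terminal phenyl ring: an acetyl or a methylcarbamoyl on the same nitrogen would separate the two, and a carboxylic acid at the end of a longer chain would show whether other extensions from this nitrogen fare the same way. Also open, from the compounds shown here alone, is whether the methyl on the aniline nitrogen of compound 1 changes the outcome of this extension, and a single-concentration read-out gives no potency for any of the compounds.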